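This account rests on a few compounds, and the source may have more. Where it says the series, first, only, none or still open, it means among the compounds named here.

Working notes on a small urea series sharing one core. Compound 1 `COc1cc(-c2nn(-c3cccc(NC(=O)Nc4cc(C(F)(F)F)cc(C(F)(F)F)c4)c3)cc2-c2ccncc2)ccc1Cl` in a functional assay on Hs-578T cells (Homo sapiens) for inhibition, read by sulforhodamine B assay, with a stated time of 48 h (a higher number here means a weaker inhibitor of growth, a lower number a stronger inhibitor of growth), gives 3680 nM for compound 1. Compound 2 `O=C(Nc1cccc(-n2cc(-c3ccncc3)c(-c3ccc(Cl)c(O)c3)n2)c1)Nc1cc(C(F)(F)F)cc(C(F)(F)F)c1` differs from compound 1 by hydrogen in place of methyl on an oxygen on an aromatic ring, and in this assay compound 2 gives 4080 nM; the step of a 1.1-fold higher number from compound 1 to compound 2 (0.04 log units; within the scatter) is small. Compound 3 `COc1cc(-c2nn(-c3cccc(NC(=O)Nc4ccc(Cl)c(C(F)(F)F)c4)c3)cc2-c2ccncc2)ccc1Cl` stands on a different core; the difference between the two cores is not broken down here. In this assay compound 3 gives 18300 nM, the highest of the three numbers and beyond the scatter from both compound 1 and compound 2.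

Compound 4 `O=C(Nc1cccc(-n2cc(-c3ccncc3)c(-c3ccc(Cl)c(O)c3)n2)c1)Nc1ccc(Cl)c(C(F)(F)F)c1` has not yet been measured. It differs from compound 3 by hydrogen in place of methyl on an oxygen on an aromatic ring, the same change as between compound 1 and compound 2, at a place described in the same words. A step of similar size is expected, a 1.1-fold higher number from compound 3 to compound 4 (0.03 log units; within the scatter), because the earlier one was a 1.1-fold higher number from compound 1 to compound 2 (0.04 log units; within the scatter) and within the scatter. Compound 4 is therefore estimated at 19500 nM in this assay, with an expected range from 9000 nM to 42000 nM.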

Compound 4, concentration for total growth inhibition: 11200 nM
Beside the measured number, compound 4's estimate is 1.7-fold (0.24 log units) above it; the measured number falls inside the stated range.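

In this assay, the change from methoxy to hydroxy on the core of compound 3 gives a 1.6-fold lower number from compound 3 to compound 4 (0.21 log units; within the scatter), so the step is again within the scatter. Set beside the earlier step, it does not differ from it: the same change on two cores in this assay, a 1.1-fold higher number (0.04 log units; within the scatter) from compound 1 to compound 2 and a 1.6-fold lower number (0.21 log units; within the scatter) from compound 3 to compound 4, 1.8-fold (0.26 log units) apart, within the scatter of two such steps. On these two cores, the change from 4-chloro-3-methoxyphenyl to 4-chloro-3-hydroxyphenyl therefore carries over as a step within the scatter, but two pairs in a single assay do not show that it would do so on other cores or in other assays, and they do not rule out a small effect hidden within the scatter.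

The compounds shown leave open whether a group other than methoxy or hydroxy at this place on the aromatic ring, such as an amine, a carboxylic acid or a longer alkoxy chain, would also leave the number unmoved. They also leave open how far the two cores themselves account for the gap between their numbers.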